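Swapping pyridin-3-yl for pyridin-4-yl on compound 2

The source may report more compounds than this note shows. Statements on the series, on what has been measured and on what is new or still open speak of the compounds shown alone.

Within the data shown here, in a functional assay for inhibition, with a stated time of 30 min (a lower number here means a stronger inhibitor, a higher number a weaker inhibitor), compound 2 (`c1ccc(-c2[nH]c3ccccc3c2C2CC(c3cccnc3)=NN2)cc1`) gives 13.6 ug/mL, the lowest number of the three measured so far. Compound 1 (`c1ccc(-c2[nH]c3ccccc3c2C2CC(c3ccncc3)=NO2)cc1`) gives 59.9 ug/mL and compound 3 (`c1ccc(-c2[nH]c3ccccc3c2C2CC(c3cccnc3)=NO2)cc1`) gives 60.7 ug/mL, both clearly higher. Compound 4 (`c1ccc(-c2[nH]c3ccccc3c2C2CC(c3ccncc3)=NN2)cc1`) has pyridin-4-yl in place of pyridin-3-yl on a carbon with a double bond to nitrogen. Among the measured compounds shown here, the one measured step involving this swap, run the other way on a different core, was a 1.0-fold higher number from compound 1 to compound 3 (0.01 log units; within the scatter). The swap remains unmeasured on the core of compound 2, so this is only indirect evidence. In this assay, no change beyond the scatter is therefore expected, with an estimated 1.0-fold higher number from compound 2 to compound 4 (0.01 log units; within the scatter). Compound 4 is estimated at 14 ug/mL, with an expected range from 6.5 ug/mL to 30 ug/mL.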

Compound 4, half-maximal inhibitory concentration: 15.8 ug/mL
Compound 4: the middle estimate sits 1.1-fold (0.05 log units) below what was measured, and the stated range covers the measured number.
By their numbers in this assay, from the lowest: compounds 2 and 4 (each within the scatter of the next); then compounds 1 and 3 (each within the scatter of the next).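

In this assay, the swap between pyridin-3-yl and pyridin-4-yl now has a reading on a second core, with a 1.2-fold higher number from compound 2 to compound 4 (0.07 log units; within the scatter). On a carbon with a double bond to nitrogen, the two groups are therefore interchangeable within the scatter on both cores shown, and the size of the swap's effect agrees between those cores: the same change on two cores in this assay, a 1.0-fold higher number (0.01 log units; within the scatter) from compound 1 to compound 3 and a 1.2-fold lower number (0.07 log units; within the scatter) from compound 4 to compound 2, 1.2-fold (0.07 log units) apart, within the scatter of two such steps

The compounds shown leave open whether this position needs a pyridine at all. Pyridin-2-yl, a plain phenyl ring or a phenyl ring carrying an amine could each test this.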